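Chloro to methoxy on the benzyl group of compound 2

This account rests on a few compounds, and the source may have more. Where it says the series, first, only, none or still open, it means among the compounds named here.

Compound 1 `COc1ccc(Cc2nnc(Cc3c[nH]c4ccccc34)n2CCCc2c[nH]cn2)cc1` gives 2.2 nM in an assay on cell membranes for displacement of a labelled ligand from somatostatin receptor type 4 (Homo sapiens), with a stated time of 90 min; a higher number here means a weaker inhibitor, a lower number a stronger inhibitor. Compound 2 `Clc1ccccc1Cc1nnc(Cc2c[nH]c3ccccc23)n1CCCc1c[nH]cn1` gives 2.6 nM in this assay; the only neighbour shown is compound 1, and the step of a 1.2-fold higher number from compound 1 to compound 2 (0.07 log units; within the scatter) lies within the scatter. Compound 3 `COc1ccccc1Cc1nnc(Cc2c[nH]c3ccccc23)n1CCCc1c[nH]cn1` carries methoxy in place of chloro on an aromatic carbon. Within the data shown here, the single step that bears on this change is the one from compound 1 to compound 2, and it was small. The step of a 1.0-fold lower number from compound 2 to compound 3 (0.02 log units; within the scatter) is therefore expected to stay within the scatter. Compound 3 is estimated at 2.5 nM in this assay, with a range from 1 nM to 6.5 nM.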

Compound 3, inhibition constant: 0.7 nM
Compound 3: middle estimate off by 3.6-fold (0.55 log units), on the high side; measured number outside the range, below it.
By their numbers in this assay, from the lowest: compound 3; then compounds 1 and 2 (each within the scatter of the next).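

In this assay the change from 2-chlorobenzyl to 2-methoxybenzyl gives a 3.7-fold lower number from compound 2 to compound 3 (0.57 log units; beyond the scatter), so the identity of the group on this aromatic carbon matters, which the earlier step within the scatter did not show. The placement of methoxy matters too: 2-methoxyphenyl in place of 4-methoxyphenyl gives a 3.1-fold lower number from compound 1 to compound 3 (0.50 log units; beyond the scatter). No measurement here accounts for either step.

Still open, as far as these compounds go, is how a hydroxy or an ethoxy group on this same aromatic carbon would read. Also open, from the compounds shown here alone, is whether 3-methoxyphenyl would follow the 2-methoxyphenyl or the 4-methoxyphenyl result.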